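Adding one methyl: an expectation for compound 3

A few compounds are considered here, and "the series" means these few. Any claim that something is new, unique, unknown or untested is made for them only; others in the source may bear on it.

Compound 1 `COc1cc(/C=C/C(=O)/C=C/c2nc3ccccc3n2C)ccc1O`: 3700 nM
Compound 2 `COc1cc(/C=C/C(=O)/C=C/c2nc3cc(C)ccc3n2C)ccc1O`: 4500 nM
Compound 3 `COc1cc(/C=C/C(=O)/C=C/c2nc3c(C)cccc3n2C)ccc1O`: not yet measured

In a functional assay on MCF7 cells (Homo sapiens) for cytotoxicity, read by MTT assay, with a stated time of 48 h (on this read-out lower numbers stand for stronger inhibition and higher numbers for weaker inhibition), compound 1 gives 3700 nM. Within the data shown here, the only other measured compound, compound 2, gives 4500 nM. These two values lie within the usual scatter of repeated measurements, so the data do not separate compound 1 from compound 2.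

Compound 3 differs from compound 1 in one place: methyl in place of hydrogen on an aromatic carbon. In short, this is methyl in place of hydrogen on an aromatic carbon. Among the measured compounds shown here, one measured step bears on this, the same kind of swap made at a different carbon: a 1.2-fold higher number from compound 1 to compound 2 (0.09 log units; within the scatter). A single step at another carbon cannot show what a methyl does at this one, so the uncertainty stays wide. No shift beyond the scatter is therefore expected in this assay, and no direction can be called with confidence. The estimated change is a 1.1-fold higher number from compound 1 to compound 3 (0.06 log units; within the scatter). For compound 3 the expected value is 4200 nM, with an estimated range from 2000 nM to 9000 nM.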

Compound 3, half-maximal inhibitory concentration: 3500 nM
For compound 3 the middle estimate is 1.2-fold (0.08 log units) above the measured one; the range from low to high includes it.
By their numbers in this assay, from the lowest: compounds 3, 1 and 2 (each within the scatter of the next).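

In this assay placing the methyl on this aromatic carbon, ortho to a fused ring, gives a 1.1-fold lower number from compound 1 to compound 3 (0.02 log units; within the scatter) and so leaves compound 3 indistinguishable from compound 1. The earlier pair covered only a methyl at a different carbon, so there are now two carbons of the six-membered aromatic ring where this one swap gives no change beyond the scatter, and neither compound 2 nor compound 3 goes against that. In this one assay, the added carbon atom at this position neither clearly helps nor clearly harms, and no measurement shown here offers an explanation for that result.

Open still is whether this position stays as undemanding with a group other than methyl, such as a longer ethyl or propyl chain, a methoxy group, a chlorine atom or an amine, any of which could give a larger step than the one seen here. Among these compounds, also open is what would happen with methyl groups on both carbons at once, since each has been seen only on its own.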